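The source may hold more compounds than are shown below. What is called first, only, known or untested is meant among the compounds shown, and "the series" means these compounds.

Values in a physicochemical assay for metabolic stability, read by HPLC and mass spectrometry, in phosphate buffer, at 37 degrees C, at pH 7.4; a lower number here means that the compound disappears faster, a higher number that the compound lasts longer:
- Compound 1 `CC(C)(O/N=C(\C(=O)N[C@@H]1C(=O)N(S(=O)(=O)O)[C@@H]1CNC(=O)CN)c1csc(N)n1)C(=O)O`: 149 h
- Compound 2 `CC(C)(O/N=C(\C(=O)N[C@@H]1C(=O)N(S(=O)(=O)O)[C@@H]1CN1CCCCC1=O)c1csc(N)n1)C(=O)O`: 214 h
- Compound 3 `CC(C)(O/N=C(\C(=O)N[C@@H]1C(=O)N(S(=O)(=O)O)[C@@H]1CN1C[C@@H](CN)OC1=O)c1csc(N)n1)C(=O)O`: > 37 h (a limit, not a number)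

Compound 3 stands at the limit of > 37 h in this assay, at which 1 of the 3 values shown sits, so its place among the values is not fixed by a number.

The change to compound 4 `CC(C)(O/N=C(\C(=O)N[C@@H]1C(=O)N(S(=O)(=O)O)[C@@H]1CN1C[C@H](CNC(=N)N)OC1=O)c1csc(N)n1)C(=O)O` is a group of 11 heavy atoms (5 carbon, 4 nitrogen, 2 oxygen; one five-membered non-aromatic ring with 2 hetero atoms) in place of a group of 8 heavy atoms (4 carbon, 2 nitrogen, 2 oxygen; one five-membered non-aromatic ring with 2 hetero atoms), on a saturated chain carbon bound to a saturated ring carbon.

Within the data shown here, no measured step covers this change directly. The closest readable evidence is a 1.4-fold higher number from compound 1 to compound 2 (0.16 log units; within the scatter), which lies within the scatter. The two steps that end on the limit give no size: a step that the limit leaves unreadable from compound 1 to compound 3, and a step that the limit leaves unreadable from compound 2 to compound 3.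

These notes therefore expect no step beyond the scatter in this assay and assign no direction. The expected step is a step that the limit leaves unreadable from compound 3 to compound 4.

Among the measured compounds shown here, the expectation leans on compound 1 at 149 h and compound 2 at 214 h, the only numbers available for the series.

For compound 4 the estimated half-life is 120 h, with an expected range of 40 h to 300 h.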

Compound 4, half-life: > 37 h
Compound 4: no number, only a limit (the forecaster's own chance of this, stated with the estimate: 40%); the middle value does not contradict the limit.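

In this assay, among these compounds, compound 4 gives > 37 h, a limit and not a number, and no step to compound 4 from compound 1, compound 2 or compound 3 can be read. The compounds shown leave open whether compound 3 and compound 4 differ from each other or from compound 1 and compound 2: the limit of > 37 h in this assay, at which 2 of the 4 values shown sit.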